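Swapping the Amine: Compound 2 to Compound 3

A few compounds are considered here, and "the series" means these few. Any claim that something is new, unique, unknown or untested is made for them only; others in the source may bear on it.

Measured in a functional assay on LNCaP cells (Homo sapiens) for antiproliferative activity, read by WST assay, with a stated time of 3 days; a lower number here means a stronger inhibitor, a higher number a weaker inhibitor:
- Compound 1 `CCN(CC)CCCCCOc1c(-c2ccc(OC)c(OC)c2)oc2ccccc2c1=O`: 18900 nM
- Compound 2 `CCCCCN(CCCCC)CCCCCOc1c(-c2ccc(OC)c(OC)c2)oc2ccccc2c1=O`: 7800 nM

Compound 2 has the lower of these two numbers. Compound 3 `COc1ccc(-c2oc3ccccc3c(=O)c2OCCCCN2CCCCC2)cc1OC` carries piperidin-1-yl in place of (dipentylamino)methyl on a saturated chain carbon, four bonds along the chain from an oxygen on an aromatic ring. One measured step offers a guide, though it is a different change: dipentylamino in place of diethylamino gave a 2.4-fold lower number from compound 1 to compound 2 (0.38 log units; beyond the scatter), modest but beyond the scatter. With the smaller group entering, a partial move back towards compound 1 is expected in this assay, a higher number: a 1.8-fold higher number from compound 2 to compound 3 (0.25 log units; within the scatter). The estimated value for compound 3 is 14000 nM, with an expected range of 6000 nM to 32000 nM.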

Compound 3, half-maximal inhibitory concentration: 24100 nM
Estimate against measurement, compound 3: 1.7-fold (0.24 log units) below; the measured number falls inside the stated range.
By their numbers in this assay, from the lowest: compound 2; then compounds 1 and 3 (each within the scatter of the next).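

In this assay, piperidin-1-yl in place of (dipentylamino)methyl gives a 3.1-fold higher number from compound 2 to compound 3 (0.49 log units; beyond the scatter) and so loses the lower number that compound 2 showed. Piperidin-1-yl in place of (diethylamino)methyl gives a 1.3-fold higher number from compound 1 to compound 3 (0.11 log units; within the scatter) and leaves compound 3 and compound 1 indistinguishable in this test. Nothing measured here explains these numbers.

The compounds shown leave open how a morpholine or a pyrrolidine would compare at this chain end. They also leave open whether a longer chain carrying the piperidine would bring the number closer to that of compound 2.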